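A few compounds are considered here, and "the series" means these few. Any claim that something is new, unique, unknown or untested is made for them only; others in the source may bear on it.

Working notes on the series. In a functional assay on K562 cells (Homo sapiens) for cytotoxicity, read by MTT assay, with a stated time of 72 h (on this read-out higher numbers stand for weaker inhibition and lower numbers for stronger inhibition), compound 1 `COCOc1cc(/C=C/C(=O)OCC(=O)Nc2ccc(OC)cc2)ccc1OCc1ccccc1` gives > 200000 nM, which is a limit and not a number. For the measured compounds named here, compound 2 `COc1ccc(NC(=O)COC(=O)/C=C/c2ccc(OCc3ccccc3)c(O)c2)cc1` gives 56100 nM, the only actual number so far in this assay.

Compound 3 `COc1ccc(NC(=O)COC(=O)/C=C/c2ccc(O)c(O)c2)cc1` is the next to consider. The change from compound 2 is hydrogen in place of benzyl on an oxygen on an aromatic ring, or benzyloxy to hydroxy.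

Going by the values given here, one measured step bears on this: an at least 3.5-fold lower number from compound 1 to compound 2 (0.55 log units; beyond the scatter), with hydrogen in place of methoxymethyl on an oxygen on an aromatic ring. Its size rests on (the limit of > 200000 nM in this assay, at which 1 of the 2 values shown sits). It involves a different group, so it is weak guidance, but a modest move to a lower number in this assay is expected on the strength of it. The expected change is a 2.2-fold lower number from compound 2 to compound 3 (0.35 log units; beyond the scatter). For compound 3 the estimate is 25000 nM, with an expected range of 8000 nM to 80000 nM.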

Compound 3, half-maximal inhibitory concentration: 79100 nM
Compound 3: the middle estimate sits 3.2-fold (0.50 log units) below what was measured; the measured number falls inside the stated range.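

In this assay, hydrogen in place of benzyl on an oxygen on an aromatic ring gives a 1.4-fold higher number from compound 2 to compound 3 (0.15 log units; within the scatter). At this place, then, the benzyl group can go without a change that can be read, so benzyloxy and hydroxy are not told apart on this read-out. The one earlier step involved methoxymethyl rather than benzyl and lay beyond the scatter, and it gave no direct reading of this change, while its size remains only a bound: the limit of > 200000 nM in this assay, at which 1 of the 3 values shown sits.

The compounds shown leave open whether any other group on this oxygen, such as methyl or acetyl, would move the number beyond the scatter. They also leave open what a change elsewhere in the shared core would do, for instance an amide in place of the ester.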